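From 3-fluorophenyl to 4-methylphenyl on a shared core

A few compounds are considered here, and "the series" means these few. Any claim that something is new, unique, unknown or untested is made for them only; others in the source may bear on it.

In an ADME assay on CHO cells (Cricetulus griseus) for cytotoxicity, read by LDH release (a lower number here means a stronger inhibitor, a higher number a weaker inhibitor), compound 1 `CC(Oc1ccc(Cl)cc1Cl)C(=O)NC(C)(C)c1ccc(F)cc1` reports > 100000 nM, which is a limit of the assay and not a number.

Within the data shown here, compound 2 `CC(Oc1ccc(Cl)cc1Cl)C(=O)NCc1cccc(F)c1` gives 27000 nM, the only true number available so far, so it is the sole fixed point for what follows. Its standing relative to compound 1 cannot be sized as a step.

Compound 3 `Cc1ccc(CNC(=O)C(C)Oc2ccc(Cl)cc2Cl)cc1` has yet to be measured in this assay. It keeps the shared core of compound 2 and carries 4-methylphenyl in place of 3-fluorophenyl on a saturated chain carbon bound to an amide-type nitrogen, a change counted as 4-methylphenyl in place of 3-fluorophenyl on a saturated chain carbon bound to an amide-type nitrogen.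

Among the measured compounds shown here, no pair of measured compounds shows what a swap of this kind does, so the data offer no size or direction for it. The expectation therefore starts from compound 2 at 27000 nM and assumes no movement beyond the scatter. The expected change, a 1.1-fold higher number from compound 2 to compound 3 (0.05 log units; within the scatter), is accordingly small, and the range around it is kept wide.

Compound 3 is estimated at 30000 nM, with an expected range of 12000 nM to 75000 nM.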

Compound 3, half-maximal inhibitory concentration: 25000 nM
The estimate for compound 3 lay 1.2-fold (0.08 log units) above the measured number; the measured number falls inside the stated range.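

Among these compounds, the first readable step at this place, on a saturated chain carbon bound to an amide-type nitrogen, is a 1.1-fold lower number from compound 2 to compound 3 (0.03 log units; within the scatter). In this assay, among the compounds shown here, compound 2 and compound 3 therefore cannot be told apart, so this exchange of 3-fluorophenyl for 4-methylphenyl, two groups of equal heavy-atom count, gives the first evidence that the two aromatic groups can stand in for each other at this place on this core. Compound 1 alone remains a limit and not a number, so no step to it can be read, and the pair of compound 2 and compound 3 lies clear of that limit: the limit of > 100000 nM in this assay, at which 1 of the 3 values shown sits.

For the compounds shown here, the single pair cannot separate the loss of the fluorine from the new methyl group or from the different ring position, and it speaks only for these two groups on this shared core. On these data alone, whether an amine or a carboxylic acid on the aromatic ring, or a longer chain bound to the amide-type nitrogen, would shift the number beyond the scatter remains open.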